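A Methoxy for Two Chlorines on the Benzyl Group

The source may report more compounds than this note shows. Statements on the series, on what has been measured and on what is new or still open speak of the compounds shown alone.

Compound 1 `Nc1cc(N)c2nc(-c3ccccc3)c(NCc3ccc(Cl)c(Cl)c3)nc2c1` gives 12900 nM in a functional assay on TK-10 cells (Homo sapiens) for inhibition, read by sulforhodamine B assay, with a stated time of 48 h; a higher number here means a weaker inhibitor of growth, a lower number a stronger inhibitor of growth.
Compound 2 `CCOC(=O)[C@H](CCC(=O)O)NC(=O)c1ccc(Sc2nc3cc(N)cc(N)c3nc2-c2ccccc2)cc1` gives 53700 nM in this assay.
Compound 3 `CCOC(=O)[C@H](CCC(=O)O)NC(=O)c1ccc(Oc2nc3cc(N)cc(N)c3nc2-c2ccccc2)cc1` gives 6310 nM in this assay.

Of the compounds shown here, three sharing one core have been measured in this assay. Compound 1 stands second highest of the three numbers. Its nearest neighbour is compound 3, whose number is lower by a margin beyond the usual scatter; furthest away is compound 2, whose number is higher, also beyond the scatter. None of these three pairs differs in only one place, so no single step can be read from them.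

Compound 4 `COc1ccc(CNc2nc3cc(N)cc(N)c3nc2-c2ccccc2)cc1` is not yet measured. It differs from compound 1 in one place: 4-methoxyphenyl in place of 3,4-dichlorophenyl on a saturated chain carbon bound to a nitrogen on an aromatic ring. For the measured compounds named here, since the measured compounds offer no comparable step, the expectation for compound 4 rests on the size of the change alone, which exchanges groups of equal atom count and alters the acceptor count by one. Compound 4 is estimated to give 18000 nM in this assay, within 6000 nM to 55000 nM. That estimate means a step from compound 1 to compound 4 of a 1.4-fold higher number from compound 1 to compound 4 (0.14 log units; within the scatter), which is expected to be a slight weakening, not clearly beyond the scatter.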

Compound 4, concentration for 50% growth inhibition: 28200 nM
For compound 4 the middle estimate is 1.6-fold (0.19 log units) below the measured one; low and high end bracket the measured number.
By their numbers in this assay, from the lowest: compound 3; then compound 1; then compounds 4 and 2 (each within the scatter of the next).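

Putting 4-methoxyphenyl in place of 3,4-dichlorophenyl on a saturated chain carbon bound to a nitrogen on an aromatic ring gives a 2.2-fold higher number from compound 1 to compound 4 (0.34 log units; beyond the scatter) in this assay, the first single-place step that can be read among these compounds. It shows that the number at this position responds to what the benzyl group carries, even though the two groups have the same heavy-atom count: with the two chlorines gone and a methoxy present, the compound is a modestly weaker inhibitor of growth. No supporting observation on these compounds explains the size or direction of this step.

As far as these compounds go, this single step cannot separate the loss of the two chlorines from the arrival of the methoxy, so it remains open how a benzyl group carrying a single chlorine, or no substituent at all, would compare with compound 1. Also open, from the compounds shown here alone, is whether a hydroxyl or a dimethylamino group on the same ring, or a longer chain in place of the single saturated carbon, would move the number in the same direction as the methoxy or in the opposite one.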